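Swapping Cyclohexyl for Isobutyl on the Amine Nitrogen

The compounds below may be only part of what the source reports. "The series", "measured", "known", "first", "only" and "open" are said of these compounds alone.

Compound 1 `COc1cc(/C=C/C(=O)/C=C(/C=C/c2ccc(OC(C)=O)c(OC)c2)NC2CCCCC2)ccc1OC(C)=O` carries a cyclohexyl group on an amine nitrogen and gives 101% in a functional assay on EA.hy 926 cells (Homo sapiens), read by fluorescence, tested at 1 uM; a higher number here means a stronger effect of the compound at the concentration tested, a lower number a weaker effect. Compound 2 `COc1cc(/C=C/C(=O)/C=C(/C=C/c2ccc(OC(C)=O)c(OC)c2)NCC(C)C)ccc1OC(C)=O` differs from it in one place, (isobutyl in place of cyclohexyl on an amine nitrogen), and in this assay compound 2 gives 104%. The step of a number 3 percentage points higher from compound 1 to compound 2 (within the scatter) therefore lies within the usual scatter of this measurement. Compound 3 `COc1cc(/C=C/C(=O)/C=C(/C=C/c2ccc(O)c(OC)c2)NC2CCCCC2)ccc1O` keeps the cyclohexyl group but rests on a different core from that of compound 1; the difference between the two cores is not broken down here. In this assay compound 3 gives 91%, which is within the scatter of compound 1 and beyond the scatter of compound 2.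

Compound 4 `COc1cc(/C=C/C(=O)/C=C(/C=C/c2ccc(O)c(OC)c2)NCC(C)C)ccc1O` has not yet been measured. It stands to compound 3 exactly as compound 2 stands to compound 1: isobutyl in place of cyclohexyl on an amine nitrogen, with the place described in the same words. Because a number 3 percentage points higher from compound 1 to compound 2 (within the scatter) stayed within the scatter, the expected step is a number 3 percentage points higher from compound 3 to compound 4 (within the scatter). For compound 4 the estimated value in this assay is 94%, within a range from 82% to 106%.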

Compound 4, a percentage reported as activity, at one concentration (the size of the read-out at that concentration, not a potency): 83%
Beside the measured number, compound 4's estimate is 11 percentage points above it, within the range that was stated.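

On the core of compound 3, isobutyl in place of cyclohexyl on an amine nitrogen gives a number 8 percentage points lower from compound 3 to compound 4 (within the scatter) in this assay, so on neither core does this change move the read-out beyond the usual scatter. Set side by side, the two steps do not separate the cores: the same change on two cores in this assay, a number 3 percentage points higher (within the scatter) from compound 1 to compound 2 and a number 8 percentage points lower (within the scatter) from compound 3 to compound 4, 11 percentage points apart, within the scatter of two such steps. The change therefore carries from one core to the other without a difference that can be told apart in this read-out, but this does not show that the two cores respond identically, and a single tested concentration says nothing about potency.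

The compounds shown leave open whether other groups on the amine nitrogen, such as a benzyl group, a longer chain or a chain ending in a hydroxyl group, would give a step beyond the scatter. They also leave open whether the same change would stay as small on any core other than these two.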